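Closing a Side Chain into a Four-Membered Ring

The compounds below may be only part of what the source reports. "The series", "measured", "known", "first", "only" and "open" are said of these compounds alone.

Compound 1 `CCCc1cc(C)c(C(=O)N=C(N)N)cc1S(C)(=O)=O` and compound 2 `CCC(C)c1cc(C)c(C(=O)N=C(N)N)cc1S(C)(=O)=O` share one core and differ only in the saturated chain attached to an aromatic carbon. In a functional assay for inhibition of sodium/hydrogen exchanger (Oryctolagus cuniculus) (on this read-out higher numbers stand for weaker inhibition and lower numbers for stronger inhibition), compound 1 gives 5.7 nM, and compound 2 gives 8 nM. Compound 2 holds the higher of the two numbers, but the gap to compound 1 lies within the scatter, so the two cannot be told apart. Compound 3 `Cc1cc(C2CCC2)c(S(C)(=O)=O)cc1C(=O)N=C(N)N` differs from compound 2 by cyclobutyl in place of sec-butyl on an aromatic carbon. For the measured compounds named here, only one measured step bears on this change: a 1.4-fold higher number from compound 1 to compound 2 (0.15 log units; within the scatter), which shows that altering the saturated chain on that aromatic carbon left the number essentially unchanged. Swapping a branched chain for a ring of the same size is expected to behave similarly, and the expected step of no change at the digits printed from compound 2 to compound 3 (within the scatter) is no larger than the scatter. Compound 3 is therefore estimated at about 8 nM, with a likely range from 3 nM to 20 nM.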

Compound 3, half-maximal inhibitory concentration: 8.2 nM
For compound 3 the middle estimate is 1.0-fold (0.01 log units) below the measured one, within the range that was stated.
By their numbers in this assay, from the lowest: compounds 1, 2 and 3 (each within the scatter of the next).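

Until now only open chains had been compared on this aromatic carbon, ortho to the methylsulfonyl group. With cyclobutyl in place of sec-butyl a four-membered ring sits there, and this assay shows a 1.0-fold higher number from compound 2 to compound 3 (0.01 log units; within the scatter), while the comparison with the unbranched propyl chain shows a 1.4-fold higher number from compound 1 to compound 3 (0.16 log units; within the scatter), so on this read-out the ring cannot be told apart from either open chain. No supporting measurement is available that would account for this match.

The three groups shown are all saturated and made of carbon only, so it remains open whether this position would stay as undemanding with an amine or a carboxylic acid there. A longer chain such as hexyl, or a larger ring such as cyclohexyl, could also give a different number.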